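Trifluoromethyl in place of hydroxy: an expected antiproliferative value

The source may hold more compounds than are shown below. What is called first, only, known or untested is meant among the compounds shown, and "the series" means these compounds.

Measured in a functional assay on HT-29 cells (Homo sapiens) for antiproliferative activity, with a stated time of 48 h; a higher number here means that more compound is needed for the effect, a lower number that less compound is needed:
compound 1 `Nc1ccc(NC(=O)CCCCCCC(=O)NO)cc1`: 18000 nM
compound 2 `O=C(CCCCCCC(=O)Nc1ccc(O)cc1)NO`: 15000 nM

Compound 2 stands at 15000 nM, and compound 1 at 18000 nM lies within the scatter of it, so the two cannot be ranked. The next compound is compound 3 `O=C(CCCCCCC(=O)Nc1ccc(C(F)(F)F)cc1)NO`, which carries trifluoromethyl in place of hydroxy on an aromatic carbon, para to a large group: trifluoromethyl in place of hydroxy on an aromatic carbon.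

For the measured compounds named here, only one measured step bears on this change. That step, a 1.2-fold lower number from compound 1 to compound 2 (0.08 log units; within the scatter), is hydroxy in place of amino on an aromatic carbon, and it lies within the scatter. Going by the values given here, it is only a partial guide, as no measured compound carries trifluoromethyl. On this evidence, no step beyond the scatter is expected in this assay, with a slight lean towards a lower number that the two measured compounds cannot settle. The expected change is a 1.3-fold lower number from compound 2 to compound 3 (0.10 log units; within the scatter). For compound 3 the estimate is 12000 nM, with an expected range from 5000 nM to 26000 nM.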

Compound 3, half-maximal effective concentration: 1400 nM
Estimate against measurement, compound 3: 8.6-fold (0.93 log units) above; measured number below the stated range.
By their numbers in this assay, from the lowest: compound 3; then compounds 2 and 1 (each within the scatter of the next).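

In this assay, the aromatic carbon para to a large group proves sensitive to what it carries, a point the earlier pair could not show: its swap of amino for hydroxy gave only a 1.2-fold lower number from compound 1 to compound 2 (0.08 log units; within the scatter), whereas trifluoromethyl in place of hydroxy gives an 11-fold lower number from compound 2 to compound 3 (1.03 log units; beyond the scatter). Trifluoromethyl in place of amino gives a similar result, a 13-fold lower number from compound 1 to compound 3 (1.11 log units; beyond the scatter), so compound 3 stands apart from both compounds that carry a hydrogen-bond donor and acceptor at this place, and those two cannot be ranked against each other. Nothing in the available data explains why this replacement has so large an effect.

For the compounds shown here, the three compounds cannot show whether the lower number is particular to trifluoromethyl or would also appear with a chlorine, a methyl or a nitrile at the same carbon, since only three groups are compared there. They also leave open whether the effect of trifluoromethyl would hold with a longer chain, or with a group other than the hydroxamic acid at the end of the chain.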